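Ecdysone receptor agonists: a halogen swap on the hydrazide

A few compounds are considered here, and "the series" means these few. Any claim that something is new, unique, unknown or untested is made for them only; others in the source may bear on it.

Compound 1 `CC(C)(C)N(NC(=O)c1ccccc1)C(=O)c1ccccc1C(F)(F)F`: 631 nM
Compound 2 `CC(C)(C)N(NC(=O)c1ccccc1)C(=O)c1ccc(Cl)cc1Cl`: 117 nM
Compound 3 `CC(C)(C)N(NC(=O)c1ccccc1Cl)C(=O)c1ccccc1Cl`: 331 nM

In an assay on cells for agonist activity at ecdysone receptor (Bombyx mori), read by a luciferase reporter, with a stated time of 24 h (on this read-out higher numbers stand for an effect only at larger amounts of compound and lower numbers for an effect already at smaller amounts), compound 3 gives 331 nM, the second highest of the three numbers. Compound 1 lies nearest, within the scatter, while compound 2 sits furthest away, beyond the scatter. Compound 4 `CC(C)(C)N(NC(=O)c1ccc(F)cc1)C(=O)c1ccccc1Cl` differs from compound 3 in one place: 4-fluorophenyl in place of 2-chlorophenyl on a carbonyl carbon. Within the data shown here, no measured pair of compounds shares this change, so the expectation rests on the narrow spread seen so far. The step from compound 3 to compound 4 is expected to be small, perhaps slightly downward but likely not beyond the scatter, at a 1.3-fold lower number from compound 3 to compound 4 (0.12 log units; within the scatter). Compound 4 is therefore estimated at 250 nM, with a range from 80 nM to 800 nM.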

Compound 4, half-maximal effective concentration: 389 nM
Compound 4: middle estimate off by 1.6-fold (0.19 log units), on the low side; the range from low to high includes it.
By their numbers in this assay, from the lowest: compound 2; then compounds 3, 4 and 1 (each within the scatter of the next).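

At this place, on a carbonyl carbon whose other neighbours are an amide-type nitrogen, 4-fluorophenyl in place of 2-chlorophenyl gives a 1.2-fold higher number from compound 3 to compound 4 (0.07 log units; within the scatter) in this assay. Among these compounds, this is the first step between two measured compounds that differ in one place, and it shows that this read-out does not separate these two groups in this pair. Nothing at hand bears on a reason for this result. As far as these compounds go, it remains open how a group such as an amine or a carboxylic acid would read at this place, and whether this swap would give a similar step with a different group on the other carbonyl carbon.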